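The compounds below may be only part of what the source reports. "The series", "measured", "known", "first", "only" and "open" are said of these compounds alone.

Series notes. Compound 1 `COc1ccc(-n2ccc(=O)c(C(=O)Nc3ccc(Oc4ccnc5[nH]ccc45)cc3)n2)cc1` gives the highest number of the two measured in a functional assay on A549 cells (Homo sapiens) for cytotoxicity, read by MTT assay, with a stated time of 72 h (on this read-out higher numbers stand for weaker inhibition and lower numbers for stronger inhibition), at 53100 nM. Going by the values given here, compound 2 `O=C(Nc1ccc(Oc2ccnc3[nH]ccc23)cc1)c1nn(-c2ccc(Br)cc2F)ccc1=O` gives 26100 nM in this assay; the step of a 2.0-fold lower number from compound 1 to compound 2 (0.31 log units; beyond the scatter) is the only measured change on the aromatic nitrogen of the shared core.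

Compound 3 `O=C(Nc1ccc(Oc2ccnc3[nH]ccc23)cc1)c1nn(-c2ccc(Cl)c(F)c2)ccc1=O` has not yet been measured. It differs from compound 1 in one place: 4-chloro-3-fluorophenyl in place of 4-methoxyphenyl on an aromatic nitrogen. Among the compounds with values here, the one step that bears on it is a 2.0-fold lower number from compound 1 to compound 2 (0.31 log units; beyond the scatter), where a halogenated phenyl likewise replaced the 4-methoxyphenyl. Taken at face value, a step of similar size and direction is expected for compound 3 in this assay, because the move from compound 1 to compound 2 gave a 2.0-fold lower number from compound 1 to compound 2 (0.31 log units; beyond the scatter); one step is thin ground, so the range is kept wide.

The estimate for compound 3 in this assay is 28000 nM, between 12000 nM and 65000 nM, which means an expected step of a 1.9-fold lower number from compound 1 to compound 3 (0.28 log units; within the scatter).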

Compound 3, half-maximal inhibitory concentration: 2580 nM
Beside the measured number, compound 3's estimate is 11-fold (1.04 log units) above it, outside the stated range (below it).
By their numbers in this assay, from the lowest: compound 3; then compound 2; then compound 1.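

The step of a 21-fold lower number from compound 1 to compound 3 (1.31 log units; beyond the scatter) in this assay shows that the group on this aromatic nitrogen can move the number much further than the first change suggested. Halogen on the phenyl is not enough to give that result: the step of a 10-fold lower number from compound 2 to compound 3 (1.01 log units; beyond the scatter) separates two halogenated groups, 4-bromo-2-fluorophenyl and 4-chloro-3-fluorophenyl, so the identity and placement of the halogens matter in this pair. No measured evidence accounts for this difference.

The compounds shown do not separate the exchange of bromine for chlorine from the different placement of the halogens on the phenyl. From the compounds shown here alone, it also remains open whether a simple 4-chlorophenyl, or a phenyl carrying a dimethylamino group, would keep the number near that of compound 3.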